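A para-iodo substituent tested on two isomeric cores

This account rests on a few compounds, and the source may have more. Where it says the series, first, only, none or still open, it means among the compounds named here.

The study compares four anilino-substituted compounds built on two closely related cores. Compound 1 has the structure `O=C1C(Nc2ccc(I)cc2)=CC(=O)c2c1nc1n2[C@H]2OC[C@@H](O)[C@H]2OC1` and compound 2 the structure `O=C1C(Nc2ccccc2)=CC(=O)c2c1nc1n2[C@H]2OC[C@@H](O)[C@H]2OC1`; they share one core and differ only in that compound 1 carries iodo in place of hydrogen on an aromatic carbon. Compound 3, with the structure `O=C1C=C(Nc2ccccc2)C(=O)c2c1nc1n2[C@H]2OC[C@@H](O)[C@H]2OC1`, has the same atoms as compound 2 joined differently, and the difference between the two cores is not broken down here. Compound 4, with the structure `O=C1C=C(Nc2ccc(I)cc2)C(=O)c2c1nc1n2[C@H]2OC[C@@H](O)[C@H]2OC1`, is the iodinated partner of compound 3 and has not yet been measured.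

In a functional assay on MCF7 cells (Homo sapiens) for inhibition, read by sulforhodamine B assay (a higher number here means a weaker inhibitor, a lower number a stronger inhibitor), compound 1 gives 3890 nM. In this assay compound 2 gives only a limit, > 4000 nM. In this assay compound 3 likewise gives only a limit, > 4000 nM. For the measured compounds named here, the one measured step, an at least 1.0-fold lower number from compound 2 to compound 1 (0.01 log units; that floor lies within the scatter), therefore cannot be read as a real change, and that floor rests on (the limit of > 4000 nM in this assay, at which 2 of the 3 values shown sit).

The change from compound 3 to compound 4 is iodo in place of hydrogen on an aromatic carbon, the same kind of change as that from compound 2 to compound 1, at the same place in the words given. Since compound 3 itself sits at the limit and the matching step on the other core stayed within scatter, compound 4 is expected to land close to the limit as well. Compound 4 is estimated at about 5000 nM, with a likely range from 2500 nM to 20000 nM. For compound 4 this estimate means an expected step that the limit leaves unreadable from compound 3 to compound 4.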

Compound 4, half-maximal inhibitory concentration: 2230 nM
Estimate against measurement, compound 4: 2.2-fold (0.35 log units) above, outside the stated range (below it).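

Setting iodo in place of hydrogen on an aromatic carbon of the core of compound 3 gives an at least 1.7-fold lower number from compound 3 to compound 4 (0.25 log units; that floor lies within the scatter) in this assay. On both cores the iodinated compound therefore has a measured value while its partner without iodine stands at a limit, which fits the change carrying over from one core to the other, although neither step is shown to exceed the scatter: the same change on two cores in this assay, an at least 1.0-fold lower number (0.01 log units; that floor lies within the scatter) from compound 2 to compound 1 and an at least 1.7-fold lower number (0.25 log units; that floor lies within the scatter) from compound 3 to compound 4; the limit leaves it open whether they differ The size of each step stays unknown, and so does whether the iodo group does the same on the two cores, because both compounds without iodine rest on a limit rather than a number: the limit of > 4000 nM in this assay, at which 2 of the 4 values shown sit.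

The compounds shown leave open how far compound 2 and compound 3 really lie from their iodinated partners, and so whether iodo does anything at all in these cells beyond what repeated measurements would scatter by. They also leave open whether a bromo or chloro group, a methoxy group or a carboxylic acid on the same aromatic ring would move the value on either core, and whether any such change would behave alike on both.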